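Oxadiazole substituent change in the glutathione S-transferase P series

A few compounds are considered here, and "the series" means these few. Any claim that something is new, unique, unknown or untested is made for them only; others in the source may bear on it.

Measured compounds:
compound 1, `C=C(C)C(=O)c1ccc(OCc2nc(C)no2)cc1C`: 5000 nM
compound 2, `C=C(C)C(=O)c1ccc(OCc2nc(-c3ccc(C(F)(F)F)cc3)no2)cc1Br`: 1300 nM

In an assay on HL-60 cells for inhibition of glutathione S-transferase P (Homo sapiens) (on this read-out higher numbers stand for weaker inhibition and lower numbers for stronger inhibition), compound 1 gives 5000 nM, the highest number of the two. Within the data shown here, compound 2 gives 1300 nM in this assay, a lower number that lies beyond the scatter; no single step between the two is computed, so only the two values themselves are compared.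

Compound 3, `C=C(C)C(=O)c1ccc(OCc2nc(-c3ccccc3)no2)cc1C`, carries the change phenyl in place of methyl on an aromatic carbon of the shared core. Among the measured compounds shown here, no measured pair isolates this change. For the measured compounds named here, the only other measured compound, compound 2, carries an aryl group at that position and shows the lower number, so a moderate move toward lower numbers is expected, though less than certain.

The step from compound 1 to compound 3 is estimated at a 2.5-fold lower number from compound 1 to compound 3 (0.40 log units; beyond the scatter). Compound 3 is expected to give about 2000 nM in this assay, within a range of 700 nM to 5000 nM.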

Compound 3, half-maximal inhibitory concentration: 1970 nM
Beside the measured number, compound 3's estimate is 1.0-fold (0.01 log units) above it; the measured number falls inside the stated range.
By their numbers in this assay, from the lowest: compounds 2 and 3 (each within the scatter of the next); then compound 1.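

In this assay, among these compounds, phenyl in place of methyl on the aromatic carbon between two ring nitrogen atoms gives a 2.5-fold lower number from compound 1 to compound 3 (0.40 log units; beyond the scatter), the first step that isolates this position. An unsubstituted phenyl is therefore enough for a step beyond the scatter, with neither the trifluoromethyl group nor the bromine of compound 2 present. Nothing measured here accounts for the step.

Compound 2 differs from compound 3 in two places, so the separate contributions of the trifluoromethyl group and of bromine in place of methyl remain unresolved. Also open, from the compounds shown here alone, is how this position responds to a pyridyl ring, an amine, a carboxylic acid or a longer alkyl chain.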